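The compounds below may be only part of what the source reports. "The series", "measured", "known", "first", "only" and "open" are said of these compounds alone.

In an ADME assay on MCF-10A cells (Homo sapiens) for cytotoxicity, read by sulforhodamine B assay, with a stated time of 48 h (on this read-out higher numbers stand for weaker inhibition of growth and lower numbers for stronger inhibition of growth), compound 2 `O=C1C(=O)N(CN2CCCCC2)c2cccc(Cl)c21` gives 70700 nM; the only other number shown belongs to compound 1 `O=C1C(=O)N(CN2CCCCC2)c2cccc(Br)c21`, which gives 66900 nM, and the step of a 1.1-fold higher number from compound 1 to compound 2 (0.02 log units; within the scatter) lies within the scatter. Compound 3 `CN(C)CN1C(=O)C(=O)c2c(Cl)cccc21` carries dimethylamino in place of piperidin-1-yl on a saturated chain carbon bound to an amide-type nitrogen in a ring. Within the data shown here, no measured step touches the amine on that chain carbon; the single measured step concerns only the halogen on the aromatic ring and was itself within the scatter. With nothing pointing in either direction, the expected step is a 1.0-fold lower number from compound 2 to compound 3 (0.00 log units; within the scatter), none beyond the scatter. The estimate for compound 3 is 70000 nM, within 30000 nM to 160000 nM.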

Compound 3, concentration for 50% growth inhibition: 82300 nM
Compound 3: middle estimate off by 1.2-fold (0.07 log units), on the low side; the measured number falls inside the stated range.
By their numbers in this assay, from the lowest: compounds 1, 2 and 3 (each within the scatter of the next).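

In this assay, among these compounds, the swap of piperidin-1-yl for dimethylamino on a saturated chain carbon bound to an amide-type nitrogen in a ring gives a 1.2-fold higher number from compound 2 to compound 3 (0.07 log units; within the scatter) and so provides the first reading at this position, which the earlier halogen step did not touch. Removing the six-membered non-aromatic ring leaves this pair within the scatter. No measured property is available to bear on this result. Still open, on these data alone, is whether a morpholin-4-yl group or a longer chain at this chain carbon would also stay within the scatter. Also open, as far as these compounds go, is whether dimethylamino behaves the same with bromo on the aromatic carbon.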